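Working notes: the step from compound 2 to compound 3

The source may report more compounds than this note shows. Statements on the series, on what has been measured and on what is new or still open speak of the compounds shown alone.

compound 1 `Cc1cc(C)cc(S(=O)(=O)n2c(SCC(=O)Nc3ccccc3S(N)(=O)=O)nc3ccccc32)c1`: 25000 nM
compound 2 `Cc1cc(C)cc(S(=O)(=O)n2c(SCC(=O)Nc3ccc(S(C)(=O)=O)cc3)nc3ccccc32)c1`: 10600 nM

Among the measured compounds shown here, in an ADME assay on MT4 cells (Homo sapiens) for cytotoxicity, read by MTT assay, with a stated time of 5 days (on this read-out lower numbers stand for higher toxicity in this test and higher numbers for lower toxicity in this test), compound 2 gives 10600 nM, the lowest of the two numbers so far. Compound 3 `Cc1cc(C)cc(S(=O)(=O)n2c(SCC(=O)Nc3ccc(S(N)(=O)=O)cc3Cl)nc3ccccc32)c1` carries 2-chloro-4-sulfamoylphenyl in place of 4-(methylsulfonyl)phenyl on an amide-type nitrogen. For the measured compounds named here, one measured step bears on this change, the modest 2.4-fold lower number from compound 1 to compound 2 (0.37 log units; beyond the scatter), where 4-(methylsulfonyl)phenyl replaced 2-sulfamoylphenyl. Going by the values given here, no measured compound shows the effect of the chlorine. A small rise is therefore expected, perhaps none beyond the scatter. The expected change is a 1.5-fold higher number from compound 2 to compound 3 (0.18 log units; within the scatter). Compound 3 is estimated at 16000 nM, with an expected range of 7000 nM to 35000 nM.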

Compound 3, half-maximal cytotoxic concentration: 25600 nM
The estimate for compound 3 lay 1.6-fold (0.20 log units) below the measured number; the range from low to high includes it.
By their numbers in this assay, from the lowest: compound 2; then compounds 1 and 3 (each within the scatter of the next).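

In this assay, the exchange on the amide-type nitrogen gives a 2.4-fold higher number from compound 2 to compound 3 (0.38 log units; beyond the scatter), so 4-(methylsulfonyl)phenyl stays alone at the low end of these three compounds. Moving to the chlorinated group from 2-sulfamoylphenyl gives a 1.0-fold higher number from compound 1 to compound 3 (0.01 log units; within the scatter), which leaves these two sulfamoyl-bearing groups indistinguishable here. Nothing available explains these results.

Going by these compounds, the separate contribution of the chlorine remains open. Also open, on these data alone, is whether plain 4-sulfamoylphenyl, or a phenyl bearing a carboxylic acid, would sit with compound 2 or with compound 1 and compound 3.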